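Aryl group exchange at compound 2

This account rests on a few compounds, and the source may have more. Where it says the series, first, only, none or still open, it means among the compounds named here.

Compound 1 `CN(C)c1cccc(C(c2ccc(F)cc2)N2CCCCC2)c1O`: in an assay for inhibition of protein disulfide-isomerase (Homo sapiens), with a stated time of 1 h (a higher number here means a weaker inhibitor, a lower number a stronger inhibitor), compound 1 gives > 30000 nM, which is a limit of the assay.
Compound 2 `Cc1ccnc(NC(c2ccccc2F)c2ccc3cccnc3c2O)c1`: in this assay compound 2 gives 880 nM.
Compound 3 `COc1ccccc1NC(c1ccccc1)c1ccc2cccnc2c1O`: in this assay compound 3 gives 390 nM.

Compound 2 holds the higher of the two numbers in this assay; compound 3 sits lower, and that gap lies beyond the scatter. The value of compound 1 is only a limit. Compound 4 `CCc1ccc(C(Nc2cc(C)ccn2)c2ccc3cccnc3c2O)cc1` differs from compound 2 in one place: 4-ethylphenyl in place of 2-fluorophenyl on a saturated chain carbon bound to an aromatic carbon and a nitrogen on an aromatic ring. For the measured compounds named here, no step between two measured compounds covers this change, so its size is not known from the measured data. Compound 4 is expected to sit close to compound 2 in this assay, the step of a 1.1-fold lower number from compound 2 to compound 4 (0.04 log units; within the scatter) being expected to stay within the usual scatter, in no clear direction. The estimate for compound 4 is 800 nM, with a range from 200 nM to 3000 nM.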

Compound 4, half-maximal inhibitory concentration: 5390 nM
Beside the measured number, compound 4's estimate is 6.7-fold (0.83 log units) below it; measured number above the stated range.
By their numbers in this assay, from the lowest: compound 3; then compound 2; then compound 4. At a limit, above all of these: compound 1.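

In this assay, putting 4-ethylphenyl in place of 2-fluorophenyl on the saturated chain carbon gives a 6.1-fold higher number from compound 2 to compound 4 (0.79 log units; beyond the scatter), the first step read at this position, and it shows that the number responds to the aryl group there. This single exchange removes the fluorine and adds the ethyl group together, so it cannot show what either change does alone.

Going by these compounds, whether 2-ethylphenyl, 4-fluorophenyl or a saturated ring such as cyclohexyl would stay nearer compound 2 or compound 4 remains open. Nothing measured here bears on why the number rises.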